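Hydroxy on the ethoxy chain of compound 3

The source may report more compounds than this note shows. Statements on the series, on what has been measured and on what is new or still open speak of the compounds shown alone.

In an ADME assay on microsomes from liver (Homo sapiens) for metabolic stability (on this read-out higher numbers stand for fast clearance and lower numbers for slow clearance), compound 1 (`O=C(Nc1cccc(Cl)c1)N1CCc2[nH]nc(-c3ccccc3)c2C1`) gives 192 mL/min/kg, compound 2 (`CCN(C)C(=O)c1n[nH]c2c1CN(C(=O)Nc1cccc(Cl)c1)CC2`) gives 87 mL/min/kg and compound 3 (`CCON(C)C(=O)c1n[nH]c2c1CN(C(=O)Nc1cccc(Cl)c1)CC2`) gives 55 mL/min/kg. Compound 3 therefore sits within the scatter of compound 2, and both stand clear of compound 1. Replacing phenyl on the aromatic carbon gave modest steps: a 2.2-fold lower number from compound 1 to compound 2 (0.34 log units; beyond the scatter) and a 3.5-fold lower number from compound 1 to compound 3 (0.54 log units; beyond the scatter). Ethoxy in place of ethyl on the amide-type nitrogen gave a 1.6-fold lower number from compound 2 to compound 3 (0.20 log units; within the scatter), which does not exceed the scatter.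

Compound 4 (`CN(OCCO)C(=O)c1n[nH]c2c1CN(C(=O)Nc1cccc(Cl)c1)CC2`) differs by one change, (hydroxy in place of hydrogen on a saturated chain carbon, two bonds along the chain from an oxygen), which turns ethoxy into 2-hydroxyethoxy. Among the measured compounds shown here, no measured step adds a hydroxy, so the data offer only indirect guidance. The closest evidence is the small change at this same substituent, a 1.6-fold lower number from compound 2 to compound 3 (0.20 log units; within the scatter), and the working expectation stays near the value of compound 3 at 55 mL/min/kg. The expected change is small, with a slight lean towards a lower number and nothing clearly beyond the scatter: a 1.3-fold lower number from compound 3 to compound 4 (0.12 log units; within the scatter). For compound 4 the estimated clearance is 42 mL/min/kg, with an expected range of 22 mL/min/kg to 80 mL/min/kg.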

Compound 4, clearance: 31 mL/min/kg
For compound 4 the middle estimate is 1.4-fold (0.13 log units) above the measured one; measured number inside the range.
By their numbers in this assay, from the lowest: compounds 4, 3 and 2 (each within the scatter of the next, the first and the last beyond it); then compound 1.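

In this assay, hydroxy on a saturated chain carbon, two bonds along the chain from an oxygen, gives a 1.8-fold lower number from compound 3 to compound 4 (0.25 log units; within the scatter), so 2-hydroxyethoxy and ethoxy are not separated on this read-out. Ethoxy in compound 3 stayed within the scatter of ethyl in compound 2, whereas 2-hydroxyethoxy gives a 2.8-fold lower number from compound 2 to compound 4 (0.45 log units; beyond the scatter), and the full replacement of phenyl now amounts to a 6.2-fold lower number from compound 1 to compound 4 (0.79 log units; beyond the scatter) in this series. No measured evidence accounts for these numbers.

Still open, as far as these compounds go, is whether this clearance level holds with a methoxy, an amine or a carboxylic acid in place of the hydroxy, or with the hydroxy on a longer chain. Also open, from the compounds shown here alone, is whether hydroxy on the ethyl of compound 2 would give a similar step.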